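The compounds below may be only part of what the source reports. "The series", "measured", "known", "first", "only" and "open" are said of these compounds alone.

Of the compounds shown here, three built on one shared core have been tested in a functional assay on A549 cells (Homo sapiens) for cytotoxicity, read by MTT assay, with a stated time of 72 h; on this read-out higher numbers stand for weaker inhibition and lower numbers for stronger inhibition. Compound 1 `COc1cccc(/C=C2\CCC/C(=C\c3ccccc3Cl)C2=O)c1OC` carries a 2-chlorophenyl. In this assay compound 1 gives > 20000 nM, which is a limit of the assay rather than a number. Compound 2 `COc1cccc(/C=C2\CCC/C(=C\c3cccc(Cl)c3)C2=O)c1OC` differs by 3-chlorophenyl in place of 2-chlorophenyl on a double-bonded chain carbon bound to a double-bonded ring carbon. In this assay compound 2 gives > 20000 nM, likewise a limit. The step that the two limits leave unreadable from compound 1 to compound 2 therefore cannot be sized. Compound 3 `COc1ccc(/C=C2\CCC/C(=C\c3ccccc3Cl)C2=O)cc1OC` keeps the 2-chlorophenyl on a core whose difference from the core of compound 1 is not broken down here. In this assay compound 3 gives > 20000 nM, again a limit. All results so far share (the limit of > 20000 nM in this assay, at which 3 of the 3 values shown sit). Compound 4 `COc1ccc(/C=C2\CCC/C(=C\c3cccc(Cl)c3)C2=O)cc1OC` is still to be measured and differs from compound 3 by 3-chlorophenyl in place of 2-chlorophenyl on a double-bonded chain carbon bound to a double-bonded ring carbon, the same change as between compound 1 and compound 2. Because the limit of > 20000 nM in this assay, at which 3 of the 3 values shown sit, leaves that earlier step unreadable, the expected step is a step that the limit leaves unreadable from compound 3 to compound 4. Compound 4 is thus estimated at 30000 nM, within 15000 nM to 80000 nM.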

Compound 4, half-maximal inhibitory concentration: 11000 nM
The estimate for compound 4 lay 2.7-fold (0.44 log units) above the measured number; the whole stated range lies above it.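

In this assay, 3-chlorophenyl in place of 2-chlorophenyl gives an at least 1.8-fold lower number from compound 3 to compound 4 (0.25 log units; that floor lies within the scatter), so on the core of compound 3 the change yields a measured number, although the floor of that step does not clear the scatter. On the core of compound 1 the same change cannot be read. The series therefore shows neither that the change carries from one core to the other nor that it fails to, because the results are mostly limits: the limit of > 20000 nM in this assay, at which 3 of the 4 values shown sit.

The compounds shown leave open whether an amine or a carboxylic acid in place of the chlorine would give a step that can be read on both cores. They also leave open whether a longer chain at that place would do so.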